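What remains when compound 2 loses its phenoxy group?

This account rests on a few compounds, and the source may have more. Where it says the series, first, only, none or still open, it means among the compounds named here.

In a functional assay on PC-3 cells (Homo sapiens) for antiproliferative activity, read by MTT assay, with a stated time of 48 h (on this read-out higher numbers stand for weaker inhibition of growth and lower numbers for stronger inhibition of growth), compound 1 `Cc1ccc(OCCCCN(Cc2ccc(C(=O)NO)cc2)c2ncc(-c3ccc(C)cc3)s2)cc1` gives 1220 nM, while compound 2 `Cc1ccc(-c2cnc(N(CCCOc3ccccc3)Cc3ccc(C(=O)NO)cc3)s2)cc1` gives 17500 nM, the higher of the two numbers and so the weaker inhibition of growth. Compound 3 `CCCN(Cc1ccc(C(=O)NO)cc1)c1ncc(-c2ccc(C)cc2)s1` has not yet been measured. It differs from compound 2 by a single change: hydrogen in place of phenoxy on a saturated chain carbon, three bonds along the chain from a nitrogen on an aromatic ring. Put simply, 3-phenoxypropyl becomes propyl. Going by the values given here, one measured step bears on this: a 14-fold higher number from compound 1 to compound 2 (1.16 log units; beyond the scatter), a large step that came with phenoxy replacing (4-methylphenoxy)methyl on a saturated chain carbon. That change kept an aromatic ring, whereas this one removes it, so the earlier step is only a loose guide. Going by these compounds, no step beyond the scatter is therefore expected in this assay, and the direction remains open. The expected step is a 1.0-fold higher number from compound 2 to compound 3 (0.01 log units; within the scatter). For compound 3, the estimated value is 18000 nM, with an expected range of 5000 nM to 60000 nM.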

Compound 3, concentration for 50% growth inhibition: 9160 nM
For compound 3 the middle estimate is 2.0-fold (0.29 log units) above the measured one; the range from low to high includes it.
By their numbers in this assay, from the lowest: compound 1; then compounds 3 and 2 (each within the scatter of the next).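

In this assay, cutting 3-phenoxypropyl back to propyl gives a 1.9-fold lower number from compound 2 to compound 3 (0.28 log units; within the scatter) and so removes the phenoxy ring without a change that stands clear of the usual scatter. Going by these compounds alone, removing (4-methylphenoxy)methyl from the same chain carbon gives a 7.5-fold higher number from compound 1 to compound 3 (0.88 log units; beyond the scatter) and shows that, of the two ring-bearing chains, only the one in compound 1 stands apart from plain propyl, so carrying an aromatic ring on this chain is not enough on its own to separate a compound from propyl. Nothing measured here accounts for this difference between the two chains.

A 4-phenoxybutyl chain would help to separate the effect of the extra chain carbon from that of the ring methyl. Going by these compounds, it also remains open whether a chain ending in an amine or a carboxylic acid would sit with propyl or with compound 1.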